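The source may hold more compounds than are shown below. What is called first, only, known or untested is meant among the compounds shown, and "the series" means these compounds.

Measured compounds in an ADME assay on Vero cells (Chlorocebus sabaeus) for cytotoxicity, read by MTT assay, with a stated time of 48 h; a higher number here means that more compound is tolerated, a lower number that less compound is tolerated:
- compound 1 `O=C(NCc1ccccc1Cl)c1ccc([N+](=O)[O-])o1`: 11000 nM
- compound 2 `CC(C)C(NC(=O)c1ccc([N+](=O)[O-])o1)c1ccccc1`: 22000 nM
- compound 3 `CC(C)(C)c1ccc(C(C)(C)NC(=O)c2ccc([N+](=O)[O-])o2)cc1`: > 150000 nM

Compound 1 and compound 2 both return numbers in this assay. Going by the values given here, compound 3 does not: its value of > 150000 nM is a limit of this assay rather than a measured number, so it is known only that compound 3 sits at the limit of > 150000 nM in this assay, at which 1 of the 3 values shown sits. Of the three compounds shown, only compound 3 reaches this limit, and therefore no measured step to or from compound 3 exists.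

Compound 4 `COc1ccc(OCc2ccc(C(C)(C)NC(=O)c3ccc([N+](=O)[O-])o3)cc2)cc1` has not yet been measured in this assay. It differs from compound 3 in one place: (4-methoxyphenoxy)methyl in place of tert-butyl on an aromatic carbon. Among the compounds with values here, no step between measured compounds is available to calibrate this change, and the two numbers that do exist, those of compound 1 and compound 2, come from compounds that are not single-step neighbours of compound 3 or compound 4.

The step from compound 3 to compound 4 is therefore expected to be modest and not clearly beyond the scatter, with the estimate an at least 2.5-fold lower number from compound 3 to compound 4 (0.39 log units; beyond the scatter) leaning towards a somewhat lower tolerated concentration. Compound 4 is estimated at 60000 nM in this assay, with an expected range from 15000 nM to 150000 nM.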

Compound 4, half-maximal cytotoxic concentration: > 120000 nM
Compound 4: only a limit was reported; the forecaster's own chance of this, stated with the estimate: 35%; middle value at least 2.0-fold (0.30 log units) from the limit.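

Compound 4 returns only a limit in this assay: the limit of > 120000 nM in this assay, at which 1 of the 4 values shown sits. Compound 3 also returns only a limit: the limit of > 150000 nM in this assay, at which 1 of the 4 values shown sits. Going by these compounds alone, with both values being limits, no step between compound 3 and compound 4 can be read. The compounds shown leave open whether (4-methoxyphenoxy)methyl in place of tert-butyl changes the tolerated concentration at all, and in which direction.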